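The source may hold more compounds than are shown below. What is called first, only, known or untested is meant among the compounds shown, and "the series" means these compounds.

Of the compounds shown here, three sharing one core have been measured in a functional assay on HEK293 cells for agonist activity at probable G-protein coupled receptor 27 (Homo sapiens), read by a luciferase reporter and beta-arrestin recruitment, with a stated time of 10 min; a lower number here means a smaller maximal response, a higher number a larger maximal response. Compound 1 `O=C(Nc1ccc(S(=O)(=O)Nc2ccccc2)cc1)c1ccc(Br)cc1F` gives 67%, compound 2 `O=C(Nc1ccc(S(=O)(=O)Nc2ccccc2)cc1)c1ccc(Cl)cc1F` gives 57%, and compound 3 `O=C(Nc1ccc(S(=O)(=O)Nc2ccccc2)cc1)c1ccc(Cl)cc1Cl` gives 100%. Compound 3 stands highest of the three in this assay: the gaps to compound 1 and to compound 2 are both beyond the scatter, while the values of compound 1 and compound 2 are within the scatter of each other, so no order can be read between those two.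

Compound 4 `Cc1cc(Br)ccc1C(=O)Nc1ccc(S(=O)(=O)Nc2ccccc2)cc1` has not yet been measured. It differs from compound 3 in one place: 4-bromo-2-methylphenyl in place of 2,4-dichlorophenyl on a carbonyl carbon.

For the measured compounds named here, three steps bear on this change. Exchanging bromo for chloro, a number 10 percentage points lower from compound 1 to compound 2 (within the scatter), changed little. Exchanging fluoro for chloro, a number 43 percentage points higher from compound 2 to compound 3 (beyond the scatter), was large, as was the combined change a number 33 percentage points higher from compound 1 to compound 3 (beyond the scatter). Going by the values given here, no measured step covers a methyl group at this position, so compound 4 is expected to fall between compound 1 and compound 3, with an estimated step of a number 18 percentage points lower from compound 3 to compound 4 (beyond the scatter). Compound 4 is therefore estimated at 82%, within a range from 58% to 105%.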

Compound 4, largest response reached (Emax), in percent of the reference or control that the assay uses: 103%
Estimate against measurement, compound 4: 21 percentage points below; the measured number falls inside the stated range.
By their numbers in this assay, from the lowest: compounds 2 and 1 (each within the scatter of the next); then compounds 3 and 4 (each within the scatter of the next).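

In this assay the step of a number 3 percentage points higher from compound 3 to compound 4 (within the scatter) shows that 4-bromo-2-methylphenyl on the carbonyl carbon can match 2,4-dichlorophenyl there. A high maximal response therefore does not depend on a chloro group at the site of the earlier fluoro-to-chloro exchange, since a methyl group serves there too. Methyl in place of fluoro gives a number 36 percentage points higher from compound 1 to compound 4 (beyond the scatter) with the bromo group kept, and the exchange of the whole group gives a number 46 percentage points higher from compound 2 to compound 4 (beyond the scatter) as well, so among these compounds the two fluoro compounds, compound 1 and compound 2, are the ones that stay lower.

From the compounds shown here alone, whether an ethyl group, a methoxy group or a plain hydrogen in place of that methyl would keep this response remains open. Nothing given here explains why methyl and chloro end up alike at this place.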